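A Smaller Amine Group in a Rat Seizure Model

The source may hold more compounds than are shown below. What is called first, only, known or untested is meant among the compounds shown, and "the series" means these compounds.

Measured compounds:
compound 1 `CNc1ncnc2c1ncn2Cc1ccc(N)cc1`: 25 mg/kg
compound 2 `Fc1ccccc1Cn1cnc2c(NCC3CC3)ncnc21`: 4.3 mg/kg

In a functional assay on the whole organism with Rattus norvegicus as the target, in the maximal electroshock model (on this read-out lower numbers stand for an effect already at smaller amounts and higher numbers for an effect only at larger amounts of compound), compound 2 gives 4.3 mg/kg, the lower of the two numbers shown. Compound 1 gives 25 mg/kg, a higher number, and the gap between compound 1 and compound 2 lies beyond the scatter. Compound 3 `CN(C)c1ncnc2c1ncn2Cc1ccccc1F` differs from compound 2 in one place: dimethylamino in place of (cyclopropylmethyl)amino on an aromatic carbon. Within the data shown here, with no measured step to rest on, the estimated step in this assay is a 2.8-fold higher number from compound 2 to compound 3 (0.45 log units; beyond the scatter), a rise in the number beyond the scatter. Compound 3 is therefore expected to give 12 mg/kg, with a range from 4 mg/kg to 40 mg/kg.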

Compound 3, dose for half-maximal effect: 8.8 mg/kg
Beside the measured number, compound 3's estimate is 1.4-fold (0.13 log units) above it; low and high end bracket the measured number.
By their numbers in this assay, from the lowest: compound 2; then compound 3; then compound 1.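

In this assay, the first step read at this position is a 2.0-fold higher number from compound 2 to compound 3 (0.31 log units; beyond the scatter), a modest change that lies beyond the scatter. On this aromatic carbon, dimethylamino, with no ring and no hydrogen-bond donor, thus keeps the number within a small step of that given by (cyclopropylmethyl)amino. Nothing at hand accounts for this step. The compounds shown do not separate the loss of the three-membered ring from the loss of the hydrogen-bond donor. Going by these compounds, how a plain amino group or a morpholine ring would behave on this carbon also remains open.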